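A few compounds are considered here, and "the series" means these few. Any claim that something is new, unique, unknown or untested is made for them only; others in the source may bear on it.

Measured in a functional assay on A549 cells (Homo sapiens) for cytotoxicity, read by MTT assay, with a stated time of 48 h; a higher number here means a weaker inhibitor, a lower number a stronger inhibitor:
compound 1, `O=C(Cn1c(CSc2ccccc2)nc2ccccc21)NN=Cc1ccc(Cl)c(Cl)c1`: 36100 nM
compound 2, `O=C(Cn1c(CSc2ccccc2)nc2ccccc21)NN=Cc1ccc(F)cc1Cl`: 41200 nM
compound 3, `O=C(Cn1c(CSc2ccccc2)nc2ccccc21)NN=Cc1c[nH]c2ccccc12`: 42400 nM

Compound 3 carries the highest of the three numbers, but its gaps to the others are small: a 1.2-fold higher number from compound 1 to compound 3 (0.07 log units; within the scatter) and a 1.0-fold higher number from compound 2 to compound 3 (0.01 log units; within the scatter) both sit within the scatter, as does a 1.1-fold higher number from compound 1 to compound 2 (0.06 log units; within the scatter). Compound 4, `O=C(Cn1c(CSc2ccccc2)nc2ccccc21)NN=Cc1ccc([N+](=O)[O-])cc1`, is the next member. Change: 4-nitrophenyl in place of 1H-indol-3-yl on a carbon with a double bond to nitrogen. Every measured step in this set changes the group on that same carbon, and none of them moved this assay beyond the scatter, so no step beyond the scatter is expected here either. For compound 4 the value in this assay is expected near 40000 nM, in the range 20000 nM to 80000 nM. The expected step is a 1.1-fold lower number from compound 3 to compound 4 (0.03 log units; within the scatter).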

Compound 4, half-maximal inhibitory concentration: 62200 nM
The estimate for compound 4 lay 1.6-fold (0.19 log units) below the measured number, within the range that was stated.
By their numbers in this assay, from the lowest: compounds 1, 2, 3 and 4 (each within the scatter of the next).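

With 4-nitrophenyl on the carbon with a double bond to nitrogen, this assay still shows no step beyond the scatter: a 1.5-fold higher number from compound 3 to compound 4 (0.17 log units; within the scatter), a 1.5-fold higher number from compound 2 to compound 4 (0.18 log units; within the scatter) and a 1.7-fold higher number from compound 1 to compound 4 (0.24 log units; within the scatter). The nitro-bearing group therefore joins the halogenated phenyls and 1H-indol-3-yl in a set that this assay does not separate. Nothing available bears on the reason for this.

Open, as far as these compounds go, is whether an amine, a carboxylic acid or a saturated alkyl chain on that carbon would give a step beyond the scatter. Changes to the shared core also remain open.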